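Ethoxy in Place of Methyl at the Carbonyl of Compound 2

A few compounds are considered here, and "the series" means these few. Any claim that something is new, unique, unknown or untested is made for them only; others in the source may bear on it.

Measured compounds:
compound 1 `COc1cc(-c2ccnc3cc(-c4ccc5cc[nH]c5c4)nn23)cc(OC)c1OC` gives 125 nM
compound 2 `COc1cc(-c2ccnc3cc(-c4ccc(C(C)=O)cc4)nn23)cc(OC)c1OC` gives 1810 nM
compound 3 `COc1cc(-c2ccnc3cc(-c4ccc5cnn(C)c5c4)nn23)cc(OC)c1OC` gives 97 nM

In a functional assay on HeLa cells (Homo sapiens) for inhibition, read by CCK-8 assay, with a stated time of 48 h (on this read-out higher numbers stand for weaker inhibition and lower numbers for stronger inhibition), compound 2 stands highest of the three numbers, meaning the weakest inhibition; the gaps are a 14-fold higher number from compound 1 to compound 2 (1.16 log units; beyond the scatter) and a 19-fold lower number from compound 2 to compound 3 (1.27 log units; beyond the scatter), both beyond the scatter. Compound 4 `CCOC(=O)c1ccc(-c2cc3nccc(-c4cc(OC)c(OC)c(OC)c4)n3n2)cc1` keeps the whole of compound 2 except for one change: ethoxy in place of methyl on a carbonyl carbon. For the measured compounds named here, no measured step touches this part of the molecule; the two known steps that start from compound 2 swap the entire aromatic group rather than the carbonyl substituent. With nothing to go on, the expected step for compound 4 is a 1.1-fold lower number from compound 2 to compound 4 (0.05 log units; within the scatter), that is, none beyond the scatter. Compound 4 is therefore estimated at 1600 nM, within a range from 600 nM to 4500 nM.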

Compound 4, half-maximal inhibitory concentration: > 10000 nM
Compound 4: no number, only a limit (the forecaster's own chance of this, stated with the estimate: 5%); middle value at least 6.2-fold (0.79 log units) from the limit.
By their numbers in this assay, from the lowest: compounds 3 and 1 (each within the scatter of the next); then compound 2. At a limit, above all of these: compound 4.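

Compound 4 gives no number in this assay, only a limit of the assay, > 10000 nM. The step is an at least 5.5-fold higher number from compound 2 to compound 4 (0.74 log units; beyond the scatter), so a small change at this carbonyl carbon, not only the swap of a whole aromatic group, can weaken inhibition beyond the scatter. How far compound 4 lies past that limit cannot be told: the limit of > 10000 nM in this assay, at which 1 of the 4 values shown sits.

The compounds shown do not tell whether this loss belongs specifically to ethoxy. From the compounds shown here alone, how a hydroxyl, giving a carboxylic acid, an amine, giving an amide, or a longer alkoxy chain would behave on this carbonyl carbon remains open.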